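A few compounds are considered here, and "the series" means these few. Any claim that something is new, unique, unknown or untested is made for them only; others in the source may bear on it.

In a functional assay on PC-3 cells (Homo sapiens) for antiproliferative activity, read by MTT assay, with a stated time of 72 h (a lower number here means a stronger inhibitor, a higher number a weaker inhibitor), compound 3 `O=C(N/N=C/c1ccccn1)c1cccc(S(=O)(=O)N2CCOCC2)c1` gives 88100 nM, the highest of the three numbers at hand. Compound 1 `C/C(=N\NC(=O)c1cccc(S(=O)(=O)N2CCOCC2)c1)c1ccc(F)cc1` gives 81300 nM, which lies within the scatter of compound 3, while compound 2 `C/C(=N\NC(=O)c1cccc(S(=O)(=O)N2CCOCC2)c1)c1ccc(O)cc1` gives 36200 nM, a number beyond the scatter below compound 3. Compound 4 `O=C(N/N=C/c1cc(Br)ccc1O)c1cccc(S(=O)(=O)N2CCOCC2)c1` differs from compound 3 in one place: 5-bromo-2-hydroxyphenyl in place of pyridin-2-yl on a carbon with a double bond to nitrogen. Among the compounds with values here, the only measured step that bears on this is the one from compound 1 to compound 2, where a hydroxy entered for a fluoro, giving a 2.2-fold lower number from compound 1 to compound 2 (0.35 log units; beyond the scatter). Within the data shown here, no measured step speaks to the bromine or to the exchange of the ring itself. Because a 2.2-fold lower number from compound 1 to compound 2 (0.35 log units; beyond the scatter) is the one shown step in which a hydroxy enters, a modest step to a lower number is expected for compound 4, about a 2.0-fold lower number from compound 3 to compound 4 (0.29 log units; within the scatter). Compound 4 is therefore estimated at 45000 nM, within a range of 12000 nM to 150000 nM.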

Compound 4, half-maximal inhibitory concentration: 7230 nM
Compound 4: the middle estimate sits 6.2-fold (0.79 log units) above what was measured, outside the stated range (below it).
By their numbers in this assay, from the lowest: compound 4; then compound 2; then compounds 1 and 3 (each within the scatter of the next).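

On a carbon with a double bond to nitrogen, 5-bromo-2-hydroxyphenyl in place of pyridin-2-yl gives a 12-fold lower number from compound 3 to compound 4 (1.09 log units; beyond the scatter) in this assay and marks this as a large step. Within the data shown here, the earlier compounds held no step in which the ring on this carbon changed, so this is the first sign that the exchange can move the number this far. Nothing measured here explains the step. On these data alone, the change brings in the carbon-only ring, the bromine and the hydroxy together, so their separate shares stay open. As far as these compounds go, whether chlorine, methoxy or an amine could stand in for the bromine or the hydroxy also stays open.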